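The source may report more compounds than this note shows. Statements on the series, on what has been measured and on what is new or still open speak of the compounds shown alone.

Measured so far:
- compound 1, `CN1CCN(CC(=O)Nc2ccc(-c3nc(-c4ccccc4)c(-c4ccccc4)n3C)cc2)CC1`, gives 28.8%
- compound 2, `Cn1c(-c2ccc(NC(=O)CN3CCN(c4ccccc4)CC3)cc2)nc(-c2ccccc2)c1-c1ccccc1`, gives 46.5%

Among the measured compounds shown here, in a functional assay on HT-29 cells (Homo sapiens) for cytotoxicity, read by MTT assay, with a stated time of 24 h, tested at 6.4 ug/mL (on this read-out lower numbers stand for a weaker effect and higher numbers for a stronger effect at the one concentration tested), compound 2 stands highest of the two numbers at hand; the nearest is compound 1, and the single step between them, a number 17.7 percentage points higher from compound 1 to compound 2 (beyond the scatter), lies beyond the scatter.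

Compound 3, `Cn1c(-c2ccc(NC(=O)CN3CCN(Cc4ccc(Cl)cc4)CC3)cc2)nc(-c2ccccc2)c1-c1ccccc1`, has not been measured. It differs from compound 2 in one place: 4-chlorobenzyl in place of phenyl on an amine nitrogen in a ring.

For the measured compounds named here, only one measured step bears on this position on the amine nitrogen in the ring, namely a number 17.7 percentage points higher from compound 1 to compound 2 (beyond the scatter), which replaced a small group by a larger aromatic one. Going by the values given here, the change to compound 3 again enlarges the group at that position, and no measured pair shows what a further enlargement of this kind does. The expectation is therefore a step of at most modest size in this assay, with no firm direction; the estimate leans slightly upward, a number 5.5 percentage points higher from compound 2 to compound 3 (within the scatter), and the range is kept wide. Compound 3 is estimated at 52%, within 30% to 72%.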

Compound 3, a percentage reported as activity, at one concentration (the size of the read-out at that concentration, not a potency): 41.5%
Compound 3: the middle estimate sits 10.5 percentage points above what was measured; the measured number falls inside the stated range.
By their numbers in this assay, from the lowest: compound 1; then compounds 3 and 2 (each within the scatter of the next).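

In this assay, the amine nitrogen in the ring has now carried three groups, and a number 5 percentage points lower from compound 2 to compound 3 (within the scatter) shows that 4-chlorobenzyl and phenyl cannot be told apart at this position, even though the entering group has 8 heavy atoms against 6 and includes a chlorine. The difference from the methyl group of compound 1 also recurs with this second aromatic group, as a number 12.7 percentage points higher from compound 1 to compound 3 (beyond the scatter) shows, so the step from compound 1 to compound 2 no longer stands as a single case. No evidence at hand explains these results.

The compounds shown do not separate the contribution of the chlorine from that of the carbon link to the ring, which plain benzyl on the same nitrogen would address, and they leave open whether an aromatic ring is needed at all, which cyclohexyl would test. A free amine hydrogen at this position is also absent from the compounds shown, so the series has no reference point without a substituent on that nitrogen.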